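The compounds below may be only part of what the source reports. "The series", "measured", "known", "first", "only" and "open" are said of these compounds alone.

In a functional assay on A549 cells (Homo sapiens) for cytotoxicity, read by MTT assay, with a stated time of 6 days (on this read-out higher numbers stand for an effect only at larger amounts of compound and lower numbers for an effect already at smaller amounts), compound 1 `COC(=O)c1c(-c2ccc(O)cc2)oc2ccc(OC)cc2c1=O` gives > 25 ug/mL, a limit and not a number. Compound 2 `O=C(O)c1c(-c2ccc([N+](=O)[O-])cc2)oc2ccccc2c1=O` gives > 25 ug/mL, likewise a limit. Compound 3 `COc1ccc2oc(-c3ccc([N+](=O)[O-])cc3)c(C(=O)O)c(=O)c2c1` stands at > 25 ug/mL, also only a limit. Going by the values given here, the series so far therefore sits in one place: the limit of > 25 ug/mL in this assay, at which 3 of the 3 values shown sit.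

The next entry is compound 4 `COc1ccc2oc(-c3ccc(O)cc3)c(C(=O)O)c(=O)c2c1`, reached from compound 3 by hydroxy in place of nitro on an aromatic carbon, para to a large group: hydroxy in place of nitro on an aromatic carbon.

Among the compounds with values here, the one measured step, a step that the two limits leave unreadable from compound 2 to compound 3, is a different change, methoxy in place of hydrogen on an aromatic carbon, and gives no size to carry over. Within the data shown here, with that step as the only guide, no step beyond the scatter is expected in this assay, and no direction can be assigned. The estimated step is a step that the limit leaves unreadable from compound 3 to compound 4. A further limit is the likeliest report. For compound 4 the expected value is 30 ug/mL, with an estimated range of 12 ug/mL to 60 ug/mL.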

Compound 4, concentration for half-maximal effect: > 25 ug/mL
Compound 4: only a limit was reported; the forecaster's own chance of this, stated with the estimate: 80%; the middle value lies beyond the limit too.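

Compound 4 adds only a limit in this assay, and the steps to it from compound 3 and from compound 1 cannot be read. The compounds shown leave open where any of them would reach a half-maximal effect, and whether any single change moves it: the limit of > 25 ug/mL in this assay, at which 4 of the 4 values shown sit.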